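From a Sulfinyl to an Aminoester on the Shared Core

The source may hold more compounds than are shown below. What is called first, only, known or untested is meant among the compounds shown, and "the series" means these compounds.

Compound 2, `C[S+]([O-])c1c(F)c(N)c2c(=O)cc(-c3ccc(N)c(F)c3)oc2c1F`, is one of three compounds built on a shared core and tested in a functional assay on HeLa cells (Homo sapiens) for cytotoxicity, read by neutral red uptake, with a stated time of 3 days; on this read-out higher numbers stand for weaker inhibition and lower numbers for stronger inhibition. In this assay compound 2 gives > 100000 nM, which is a limit of the assay and not a number. Compound 1, `Cc1c(F)c(N)c2c(=O)cc(-c3ccc(N)c(F)c3)oc2c1F`, likewise reaches only a limit, giving > 100000 nM in this assay. Within the data shown here, compound 3, `CCC(=O)OCc1c(F)c(N)c2c(=O)cc(-c3ccc(N)c(F)c3)oc2c1F`, gives 69000 nM in this assay, the only full number among the three. Two of the three values therefore sit at the limit of > 100000 nM in this assay, at which 2 of the 3 values shown sit. Compound 4, `CN(C)CCCC(=O)OCc1c(F)c(N)c2c(=O)cc(-c3ccc(N)c(F)c3)oc2c1F`, has not yet been measured; it differs from compound 2 in that (a group of 10 heavy atoms (7 carbon, 1 nitrogen, 2 oxygen; no ring) in place of a group of 3 heavy atoms (1 carbon, 1 oxygen, 1 sulfur; no ring), on an aromatic carbon). Of the measured steps, an at least 1.4-fold lower number from compound 2 to compound 3 (0.16 log units; that floor lies within the scatter) bears most directly on this change, and an at least 1.4-fold lower number from compound 1 to compound 3 (0.16 log units; that floor lies within the scatter) is of the same kind, each only a floor. Since the group entering in compound 4 carries an ester on a saturated chain carbon much as the propanoyloxy of compound 3 does, a similar outcome is expected. Compound 4 is thus estimated to give about 60000 nM, between 20000 nM and 150000 nM, in this assay, an expected step of an at least 1.6-fold lower number from compound 2 to compound 4 (0.22 log units; that floor lies within the scatter).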

Compound 4, half-maximal inhibitory concentration: 4500 nM
Compound 4: middle estimate off by 13-fold (1.12 log units), on the high side; measured number outside the range, below it.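

The earlier steps shown here to compound 3 gave only floors within the scatter, so they showed no clear effect of an ester at this position. Among these compounds, compound 4 shows that the end of the ester chain matters: in this assay, adding (dimethylamino)methyl to the propanoyloxy chain gives a 15-fold lower number from compound 3 to compound 4 (1.19 log units; beyond the scatter), the only step here between two full numbers. Against the two compounds that reach only a limit, the change appears as an at least 22-fold lower number from compound 2 to compound 4 (1.34 log units; beyond the scatter) and as an at least 22-fold lower number from compound 1 to compound 4 (1.34 log units; beyond the scatter), both beyond the scatter yet both only floors: the limit of > 100000 nM in this assay, at which 2 of the 4 values shown sit.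

The compounds shown do not separate the dimethylamino group from the longer chain that carries it. Going by these compounds, it also remains open how a primary amine, a carboxylic acid or a longer chain at the end of the ester would read in this assay.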